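A few compounds are considered here, and "the series" means these few. Any claim that something is new, unique, unknown or untested is made for them only; others in the source may bear on it.

Measured so far:
compound 1 `O=C(Nc1ccc(C(F)(F)F)cc1)Nc1ccc(-c2ccnc(NCC3CC3)c2)c(C(F)(F)F)c1` — 53.4%
compound 2 `CCCNc1cc(-c2ccc(NC(=O)Nc3cccc(Cl)c3)cc2C(F)(F)F)ccn1` — 63%

In an assay on isolated protein for inhibition of serine/threonine-protein kinase PLK1 (Homo sapiens), read by radiometric assay and 33P incorporation, with a stated time of 40 min, tested at 20 uM, in the presence of a further agent that is not named here (on this read-out lower numbers stand for less inhibition and higher numbers for more inhibition at the one concentration tested (going by the name of the read-out)), compound 1 gives 53.4% and compound 2 gives 63%. Of the two numbers in hand that of compound 2 is the upper one, but the gap to compound 1 falls within the usual scatter, so the two are not separated by this read-out.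

Compound 3 `CCCNc1cc(-c2ccc(NC(=O)Nc3ccc(C(F)(F)F)cc3)cc2C(F)(F)F)ccn1` is compound 2 with one change: 4-(trifluoromethyl)phenyl in place of 3-chlorophenyl on an amide-type nitrogen. The entering group is the same one that compound 1 carries on its urea, while the rest of compound 3 follows compound 2. Going by the values given here, no pair of measured compounds isolates this change, so its size cannot be read from a step. Given that compound 1 and compound 2 sit within the scatter of one another, no step beyond the scatter is expected in this assay in either direction. Compound 3 is estimated at 57%, range 40% to 72%, the expected step being a number 6 percentage points lower from compound 2 to compound 3 (within the scatter).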

Compound 3, a percentage reported as inhibition, at one concentration (the size of the read-out at that concentration, not a potency): 51.3%
For compound 3 the middle estimate is 5.7 percentage points above the measured one; the measured number falls inside the stated range.
By their numbers in this assay, from the lowest: compounds 3, 1 and 2 (each within the scatter of the next, the first and the last beyond it).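

In this assay, going by these compounds alone, 4-(trifluoromethyl)phenyl in place of 3-chlorophenyl on an amide-type nitrogen gives a number 11.7 percentage points lower from compound 2 to compound 3 (beyond the scatter) and is the first change at this position to be read as a step, a modest one that shows the position is not indifferent to the group it carries. Ethyl in place of cyclopropyl on a saturated chain carbon bound to a nitrogen on an aromatic ring gives a number 2.1 percentage points lower from compound 1 to compound 3 (within the scatter) and so does not separate these two groups at that place. Nothing in hand bears on the reason for either step.

On these data alone, whether the step follows the loss of the chlorine or the entry of the trifluoromethyl stays open, and a plain phenyl or a 4-chlorophenyl on the same nitrogen would bear on that. As far as these compounds go, how a longer chain or a free amine would read at the other place also stays open.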